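Halogen swaps on a pyrimidine series and liver microsome stability

This account rests on a few compounds, and the source may have more. Where it says the series, first, only, none or still open, it means among the compounds named here.

Three compounds share one core and differ only in the halogenated phenyl ring attached to it. Compound 1 is `Nc1nc(NCCNc2ncc(-c3ncc[nH]3)c(-c3ccc(F)cc3Cl)n2)ccc1[N+](=O)[O-]`, compound 2 is `Nc1nc(NCCNc2ncc(-c3ncc[nH]3)c(-c3ccc(F)cc3Br)n2)ccc1[N+](=O)[O-]` and compound 3 is `Nc1nc(NCCNc2ncc(-c3ncc[nH]3)c(-c3ccc(Cl)cc3F)n2)ccc1[N+](=O)[O-]`. In an ADME assay on microsomes from liver (Canis lupus familiaris) for metabolic stability (a lower number here means that the compound disappears faster, a higher number that the compound lasts longer), compound 1 gives > 0.5 h, which is a limit of the assay rather than a number. In this assay compound 2 likewise gives only the limit > 0.5 h. Compound 3 also reaches only the limit > 0.5 h in this assay.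

The change from compound 1 to compound 2 is bromo in place of chloro on an aromatic carbon, and its step in this assay is a step that the two limits leave unreadable from compound 1 to compound 2. The cores of compound 1 and compound 3 differ as 4-chloro-2-fluorophenyl in place of 2-chloro-4-fluorophenyl on an aromatic carbon, giving a step that the two limits leave unreadable from compound 1 to compound 3. Every step among the three is unreadable because of the limit of > 0.5 h in this assay, at which 3 of the 3 values shown sit.

Compound 4, `Nc1nc(NCCNc2ncc(-c3ncc[nH]3)c(-c3ccc(Br)cc3F)n2)ccc1[N+](=O)[O-]`, is not yet measured. Its difference from compound 3 is bromo in place of chloro on an aromatic carbon. This is the same kind of change as that from compound 1 to compound 2, but the surroundings differ: in compound 1 the swapped halogen sits ortho to a large group, whereas in compound 3 it sits para to a large group, both meta to a fluoro group.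

The step from compound 3 to compound 4 in this assay is expected to be a step that the limit leaves unreadable from compound 3 to compound 4, resting on compound 3 reaching the limit > 0.5 h. Compound 4 is therefore estimated at 1 h in this assay, most likely again reported only as a limit.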

Compound 4, half-life: > 0.5 h
Compound 4 ended at the assay's limit; the forecaster's own chance of this, stated with the estimate: 85%; the middle value lies beyond the limit too.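

In this assay compound 4 gives > 0.5 h, which is a limit and not a number. Its steps to compound 1, compound 2 and compound 3 cannot be read, because all four compounds share one limit: the limit of > 0.5 h in this assay, at which 4 of the 4 values shown sit.

The compounds shown leave open how long each one actually lasts, and whether bromo in place of chloro, or a change in halogen arrangement, alters that at all.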